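Swapping methyl for bromo on a pyrazoline series

The source may hold more compounds than are shown below. What is called first, only, known or untested is meant among the compounds shown, and "the series" means these compounds.

The measured compounds and their values:
- compound 1, `Cc1ccc(C2=NN(C3=NC(=O)CS3)C(c3ccc4ccccc4c3)C2)cc1`: 12700 nM
- compound 2, `Cc1ccc(C2=NN(C3=NC(c4ccccc4)CS3)C(c3ccc4ccccc4c3)C2)cc1`: 14700 nM
- compound 3, `Fc1ccc(C2=NN(C3=NC(c4ccccc4)CS3)C(c3cccc4ccccc34)C2)cc1`: 23200 nM

All three were tested in a functional assay on HepG2 cells (Homo sapiens) for inhibition, read by CCK-8 assay, with a stated time of 48 h; on this read-out lower numbers stand for stronger inhibition and higher numbers for weaker inhibition. Compound 1 gives the lowest of the three numbers, but both others lie within the usual scatter of it, so no order among them can be claimed. For the measured compounds named here, the one single-point step in the set, a 1.2-fold higher number from compound 1 to compound 2 (0.06 log units; within the scatter), swaps one group on the ring nitrogen of the shared core and leaves the number essentially unchanged.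

Compound 4, `O=C1CSC(N2N=C(c3ccc(Br)cc3)CC2c2ccc3ccccc3c2)=N1`, is the unmeasured compound. It differs from compound 1 in one place: bromo in place of methyl on an aromatic carbon. Going by the values given here, no measured pair in the set isolates this change. Compound 3 carries a different halogen on that ring, but it also differs from compound 2 elsewhere, so only its own value can be read from it, and that value sits within the scatter of compound 1 and compound 2.

With nothing pointing either way, compound 4 is expected to stay close to compound 1, a step of a 1.1-fold lower number from compound 1 to compound 4 (0.02 log units; within the scatter) that means no change beyond the scatter. Compound 4 is therefore estimated at 12000 nM, with a range from 5000 nM to 30000 nM.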

Compound 4, half-maximal inhibitory concentration: 18200 nM
Compound 4: middle estimate off by 1.5-fold (0.18 log units), on the low side, within the range that was stated.
By their numbers in this assay, from the lowest: compounds 1, 2, 4 and 3 (each within the scatter of the next).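

In this assay, for the compounds shown here, the pair of compound 1 and compound 4 isolates a single change on this ring, 4-methylphenyl to 4-bromophenyl, which the earlier compounds could not do. The swap brings a 1.4-fold higher number from compound 1 to compound 4 (0.16 log units; within the scatter) and so stays inside the normal spread of repeated measurements. On this core, then, methyl and bromo at this position on the aromatic carbon, para to a large group, cannot be told apart by this read-out. Nothing measured here offers an explanation for this result.

From the compounds shown here alone, what an amine, a carboxylic acid or a longer chain at the same position would do remains open. Also open, going by these compounds, is whether the same swap would read alike on the core of compound 2, which carries a different group on the ring nitrogen.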